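This account rests on a few compounds, and the source may have more. Where it says the series, first, only, none or still open, it means among the compounds named here.

The measured compounds in a functional assay on Right cardiac atrium for agonist activity at histamine H2 receptor (Cavia porcellus), with a stated time of 30 min, in the presence of a further agent that is not named here; on this read-out higher numbers stand for an effect only at larger amounts of compound and lower numbers for an effect already at smaller amounts:

compound 1, `Cc1nc(N)sc1CCCN/C(N)=N/C(=O)NC(C)c1cccc(F)c1`: 26.3 nM
compound 2, `Cc1nc(N)sc1CCCN/C(N)=N/C(=O)N[C@@H](C)c1ccccc1`: 23.4 nM
compound 3, `Cc1nc(N)sc1CCCN/C(N)=N/C(=O)NC(C)c1ccccc1F`: 12.3 nM

Among these three, compound 1 stands at the highest number. Compound 2 sits nearest to it, and the two values lie within the scatter of each other, so nothing can be said about their order. Compound 3 lies furthest away, and here there is a single-point step: a 2.1-fold lower number from compound 1 to compound 3 (0.33 log units; beyond the scatter). For the measured compounds named here, this is a modest step, just beyond the scatter, and it is the only step within this set that bears on the aromatic group attached to the saturated chain carbon.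

Compound 4, `Cc1nc(N)sc1CCCN/C(N)=N/C(=O)NC(C)c1ccco1`, has not yet been measured in this assay . It differs from compound 1 in one place: furan-2-yl in place of 3-fluorophenyl on a saturated chain carbon bound to an amide-type nitrogen and a saturated chain carbon. Going by the values given here, the one measured step concerns a move of the fluorine on the same six-membered ring, not an exchange of the ring itself, so it gives only weak guidance for this change. Since the three measured values all lie within a narrow band, compound 4 is expected to fall in the same region, with no step beyond the scatter but with wide uncertainty. The expected step of a 1.3-fold higher number from compound 1 to compound 4 (0.12 log units; within the scatter) is estimated to remain within the scatter. Compound 4 is therefore expected to give 35 nM, with a range from 12 nM to 110 nM.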

Compound 4, half-maximal effective concentration: 9.77 nM
Compound 4: middle estimate off by 3.6-fold (0.55 log units), on the high side, outside the stated range (below it).
By their numbers in this assay, from the lowest: compounds 4, 3, 2 and 1 (each within the scatter of the next, the first and the last beyond it).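

In this assay, the place on a saturated chain carbon bound to an amide-type nitrogen and a saturated chain carbon proves not to be limited to a six-membered aromatic ring of carbon only: furan-2-yl, a five-membered aromatic ring with 1 hetero atom, gives a lower number than 3-fluorophenyl (a 2.7-fold lower number from compound 1 to compound 4 (0.43 log units; beyond the scatter)). The same direction holds when 1-(furan-2-yl)ethyl replaces 1-phenylethyl on an amide-type nitrogen (a 2.4-fold lower number from compound 2 to compound 4 (0.38 log units; beyond the scatter)), whereas the exchange for 2-fluorophenyl stays within the scatter (a 1.3-fold lower number from compound 3 to compound 4 (0.10 log units; within the scatter)), so compound 3 and compound 4 cannot be put in order. No measurement at hand offers an explanation for these steps.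

The compounds shown cannot tell whether the ring oxygen of furan-2-yl matters to the result, which a comparison with thiophen-2-yl at the same place could address. They also leave open how the two mirror-image forms at the saturated chain carbon compare, since that arrangement is drawn only for compound 2.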